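The compounds below may be only part of what the source reports. "The series", "measured", "known", "first", "only" and "open" are said of these compounds alone.

Working notes on the series. Compound 1 `CC1=NN(c2ccc(C)c(C)c2)C(=O)/C1=C(/C)NNC(=S)N1CCc2cc(C(=O)N3CCOCC3)ccc21` and compound 2 `CNC(=O)c1ccc2c(c1)CCN2C(=S)NN/C(C)=C1\C(=O)N(c2ccc(C)c(C)c2)N=C1C` share one core and differ only in the amide substituent. In an assay on BaF3 cells for inhibition of thrombopoietin receptor (Homo sapiens) (on this read-out lower numbers stand for an effect already at smaller amounts and higher numbers for an effect only at larger amounts of compound), compound 1 gives 31 nM, and in this assay compound 2 gives 22 nM. The step of a 1.4-fold lower number from compound 1 to compound 2 (0.15 log units; within the scatter) is the only one recorded so far, and it stays inside the usual scatter. Compound 2 therefore holds the lowest of the two numbers, with compound 1 nearest and not separated from it beyond the scatter.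

Compound 3 `CCNC(=O)c1ccc2c(c1)CCN2C(=S)NN/C(C)=C1\C(=O)N(c2ccc(C)c(C)c2)N=C1C` follows from compound 2 by methyl in place of hydrogen on a saturated chain carbon bound to an amide-type nitrogen. For the measured compounds named here, no measured pair shows this methyl-for-hydrogen exchange on the amide nitrogen; the nearest comparison, a 1.4-fold lower number from compound 1 to compound 2 (0.15 log units; within the scatter), swapped a larger ring substituent for methylamino and changed the number only within the scatter. The step of a 1.1-fold higher number from compound 2 to compound 3 (0.06 log units; within the scatter) is expected to stay within the scatter, with no set direction. Compound 3 is estimated at 25 nM in this assay, with a range from 10 nM to 65 nM.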

Compound 3, half-maximal effective concentration: 26 nM
Compound 3: middle estimate off by 1.0-fold (0.02 log units), on the low side, and the stated range covers the measured number.
By their numbers in this assay, from the lowest: compounds 2, 3 and 1 (each within the scatter of the next).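

The methyl-for-hydrogen exchange on a saturated chain carbon bound to an amide-type nitrogen, methylamino to ethylamino, now has its own measured step in this assay: a 1.2-fold higher number from compound 2 to compound 3 (0.07 log units; within the scatter) stays within the scatter, so this added methyl does not separate the two compounds. The other new step, a 1.2-fold lower number from compound 1 to compound 3 (0.08 log units; within the scatter), also stays within the scatter, so morpholin-4-yl, methylamino and ethylamino at this place cannot be told apart in this assay on these three compounds. Nothing on hand accounts for these numbers staying together.

Open, from the compounds shown here alone, is whether a longer chain such as n-butylamino, or a chain ending in an amine or a carboxylic acid, would move the number beyond the scatter. Going by these compounds, the plain unsubstituted carboxamide also remains open as a comparison for this series.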